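Isopropyl on the Cyanoguanidine Nitrogen of a Histamine Antagonist

The source may report more compounds than this note shows. Statements on the series, on what has been measured and on what is new or still open speak of the compounds shown alone.

Two cyanoguanidines carrying the same imidazolylbutyl chain have been tested in an in vitro functional assay on Sf9 cells for antagonist activity at histamine H2 receptor (Homo sapiens); a lower number here means a less potent compound, a higher number a more potent compound, by a factor of ten per unit of this negative logarithm. Compound 1 `N#C/N=C(/NCCCCc1c[nH]cn1)NCCCc1ccccc1` carries a phenylpropyl group on the second guanidine nitrogen, and in this assay compound 1 gives 5.25. Compound 2 `N#C/N=C(\N)NCCCCc1c[nH]cn1` leaves that nitrogen unsubstituted. For compound 2 this assay reports only a limit, < 5. Compound 2 therefore stands at the lower edge of what the numbers show, which is the limit of < 5 in this assay, at which 1 of the 2 values shown sits.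

Compound 3 `CC(C)N/C(=N\C#N)NCCCCc1c[nH]cn1` is the next member of the series. It differs from compound 2 by isopropyl in place of hydrogen on an amine nitrogen. Going by the values given here, with no measured step between related pairs to draw on, the expected change is a modest gain in potency, a number at least 0.30 log units higher from compound 2 to compound 3 (that floor lies within the scatter), in the direction of compound 1. Compound 3 is estimated at 5.3 in this assay, with a range from 4.6 to 6.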

Compound 3, negative logarithm of the antagonist equilibrium constant: < 5
Compound 3 gave a limit, no number; the forecaster's own chance of this, stated with the estimate: 30%; middle value at least 0.30 log units away from the limit.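

Compound 2 and compound 3 are both reported only as limits in this assay, so no step can be read between them: the limit of < 5 in this assay, at which 2 of the 3 values shown sit.

The compounds shown leave open whether isopropyl in place of hydrogen on an amine nitrogen changes potency at all, and by how much.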